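The source may hold more compounds than are shown below. What is called first, only, known or untested is meant among the compounds shown, and "the series" means these compounds.

Measured so far:
- compound 1 `O=C(CCc1nc2ccccc2c(=O)[nH]1)N/N=C/c1ccc(O)cc1`: 238000000 nM
- compound 2 `COc1cc(/C=N/NC(=O)CCCc2nc3ccccc3c(=O)[nH]2)ccc1O`: 236000000 nM

Both values come from a physicochemical assay, read by spectrophotometry, with a stated time of 30 min; a lower number here means a stronger inhibitor, a higher number a weaker inhibitor. Compound 1 gives 238000000 nM and compound 2 gives 236000000 nM, so the two lie within the scatter of each other and compound 1 cannot be separated from compound 2 on these numbers. Among the compounds with values here, with only this pair measured, there is no wider range in which to place compound 1.

The next compound is compound 3 `COc1ccc(/C=N/NC(=O)CCc2nc3ccccc3c(=O)[nH]2)cc1`, which has methyl in place of hydrogen on an oxygen on an aromatic ring, turning 4-hydroxyphenyl into 4-methoxyphenyl. Within the data shown here, no measured step shows this change, so the expectation is weakly held. Both compound 1, at 238000000 nM, and compound 2, at 236000000 nM, carry a hydroxy group on an aromatic ring, whereas compound 3 does not. A modest move towards a higher number in this assay is therefore expected, though a result within the scatter would not be surprising. The expected size of the change is a 1.3-fold higher number from compound 1 to compound 3 (0.13 log units; within the scatter). For compound 3 the estimated value is 320000000 nM, with an expected range of 170000000 nM to 800000000 nM.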

Compound 3, half-maximal inhibitory concentration: 214000000 nM
Estimate against measurement, compound 3: 1.5-fold (0.17 log units) above, and the stated range covers the measured number.
By their numbers in this assay, from the lowest: compounds 3, 2 and 1 (each within the scatter of the next).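

In this assay, within the data shown here, the only step that changes a single place gives a 1.1-fold lower number from compound 1 to compound 3 (0.05 log units; within the scatter), so hydroxy and methoxy at this position cannot be told apart on these numbers. The pair of compound 1 and compound 2 could not show this, as those two compounds differ in more than one place, whereas here 4-hydroxyphenyl to 4-methoxyphenyl stands alone and the hydrogen on this oxygen gives way to methyl without a readable change in the half-maximal inhibitory concentration. Nothing available on this series speaks to why the step comes out this way.

Still open, as far as these compounds go, is whether a different group at this place, such as an amine, a carboxylic acid or a longer chain on the oxygen, would move the number beyond the scatter, or whether this position tolerates such groups as it does methyl. Also open, from the compounds shown here alone, is whether methyl in place of hydrogen on this oxygen reads the same on other members, such as compound 2, whose chain and ring differ from those of compound 1.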